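Adding a hydroxy group to compound 2

This account rests on a few compounds, and the source may have more. Where it says the series, first, only, none or still open, it means among the compounds named here.

In a functional assay on HOP-62 cells (Homo sapiens) for inhibition, read by sulforhodamine B assay (a lower number here means a stronger inhibitor of growth, a higher number a weaker inhibitor of growth), compound 1 `FC(F)(F)c1ccc(-c2ccc(-c3ccc(-c4nc5ccccc5[nH]4)cc3)cc2)cc1` gives 100000 nM with a trifluoromethyl group on an aromatic carbon. Compound 2 `COc1ccc(-c2ccc(-c3ccc(-c4nc5ccccc5[nH]4)cc3)cc2)cc1` gives 100000 nM with methoxy at that carbon, and compound 3 `CN(C)c1ccc(-c2ccc(-c3ccc(-c4nc5ccccc5[nH]4)cc3)cc2)cc1` gives 100000 nM with dimethylamino there. Compound 2 thus stands level with both neighbours. The three exchanges show no change at the digits printed from compound 1 to compound 2 (within the scatter) and no change at the digits printed from compound 1 to compound 3 (within the scatter) and no change at the digits printed from compound 2 to compound 3 (within the scatter) as the whole of the measured evidence.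

Compound 4 `COc1ccc(-c2ccc(-c3ccc(-c4nc5c(O)cccc5[nH]4)cc3)cc2)cc1` keeps the methoxy group of compound 2 and differs elsewhere: hydroxy in place of hydrogen on an aromatic carbon describes hydroxy in place of hydrogen on an aromatic carbon, which turns 1H-benzimidazol-2-yl into 4-hydroxy-1H-benzimidazol-2-yl. Among the measured compounds shown here, none of the measured steps touches this part of the molecule, so they bear on it only indirectly. They show that exchanges at another site left the reading unmoved, and they give no size for a change at this one. A modest move towards stronger inhibition is expected, though no change at all remains quite possible. The estimated outcome is a 3.3-fold lower number from compound 2 to compound 4 (0.52 log units; beyond the scatter) as a tentative expectation. For compound 4 the estimate is 30000 nM within an expected range of 3000 nM to 100000 nM in this assay for now.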

Compound 4, concentration for 50% growth inhibition: 3210 nM
For compound 4 the middle estimate is 9.3-fold (0.97 log units) above the measured one; the measured number falls inside the stated range.
By their numbers in this assay, from the lowest: compound 4; then compounds 1, 2 and 3 (each within the scatter of the next).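

The exchange of 1H-benzimidazol-2-yl for 4-hydroxy-1H-benzimidazol-2-yl gives a 31-fold lower number from compound 2 to compound 4 (1.49 log units; beyond the scatter) in this assay, a large step beyond the scatter. Compounds 1, 2 and 3 had shown only that trifluoromethyl, methoxy and dimethylamino read alike at a different site, whereas this result shows that the reading can move and that a single hydroxy in place of hydrogen on this aromatic carbon is enough to move it. No measurement bearing on the origin of this step is available, so the result records its size and leaves its cause unexplained.

The compounds shown do not tell whether the step belongs to hydroxy specifically, as a methoxy, an amine or a fluorine on the same carbon would test, or whether any substituent at this carbon would produce it. They also leave open whether the same hydroxy would have a similar effect alongside the trifluoromethyl group of compound 1 or the dimethylamino group of compound 3, since the step has been read only with the methoxy group of compound 2.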